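This account rests on a few compounds, and the source may have more. Where it says the series, first, only, none or still open, it means among the compounds named here.

Compound 1 `O=C(O)CCc1ccc(NCC2COc3ccc(Cl)cc3O2)cc1F`: 69%
Compound 2 `CC#C[C@H](CC(=O)O)c1ccc(OC[C@@H]2COc3ccc(Cl)cc3O2)cc1`: 41%
Compound 3 `CC#C[C@@H](CC(=O)O)c1ccc(OC[C@H]2COc3c(Cl)cccc3O2)cc1`: 81%

All three were tested in a functional assay on HEK293 cells for agonist activity at Free fatty acid receptor 1 (Homo sapiens), read by fluorescence and calcium flux, with a stated time of 10 min; a higher number here means a larger maximal response, a lower number a smaller maximal response. Compound 3 gives the highest of the three values; compound 1 is nearest and lies beyond the scatter below it, while compound 2 lies furthest below, also beyond the scatter. The account now follows the step from compound 3 to compound 4 `CC#C[C@@H](CC(=O)O)c1ccc(OC[C@H]2COc3ccccc3O2)cc1`, which has not yet been measured in this assay. The change is hydrogen in place of chloro on an aromatic carbon. Among the compounds with values here, no pair of measured compounds isolates this change, so the expectation rests on the spread of the three values alone. Because compound 3 gives 81% while the other two sit lower, a modest decrease is expected, estimated as a number 16 percentage points lower from compound 3 to compound 4 (beyond the scatter). Compound 4 is expected to give 65%, within a range of 40% to 90%.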

Compound 4, largest response reached (Emax), in percent of the reference or control that the assay uses: 70%
Estimate against measurement, compound 4: 5 percentage points below; the measured number falls inside the stated range.
By their numbers in this assay, from the lowest: compound 2; then compounds 1 and 4 (each within the scatter of the next); then compound 3.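

In this assay, within the data shown here, a single-place change can now be read for the first time: replacing chloro with hydrogen on this aromatic carbon, ortho to a fused ring and meta to a fused ring, gives a number 11 percentage points lower from compound 3 to compound 4 (beyond the scatter) and is a modest step. The maximal response therefore depends on this substituent, although the size of the step is modest. Nothing available here accounts for this difference.

On these data alone, whether fluoro, bromo or methoxy on this carbon would give a response closer to that with chloro or with hydrogen remains open. As far as these compounds go, it is also open whether the same step would appear on the core of compound 2, which has the opposite stereochemistry and its chloro elsewhere on the ring.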